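This account rests on a few compounds, and the source may have more. Where it says the series, first, only, none or still open, it means among the compounds named here.

Measured so far in a functional assay on M12 cells (Homo sapiens) for antiproliferative activity, read by WST assay, with a stated time of 72 h; a lower number here means that less compound is needed, a higher number that more compound is needed for the effect:
- compound 1 `CCCCCCCC/C=C\c1c(C)cc(C)nc1CCCOC`: 31.7 uM
- compound 2 `CCCCCCCCCCc1c(C)c(CCCCCCCCCC)c2[n+](c1C)CCC2`: 1.9 uM

Compound 2 gives 1.9 uM, the lower of the two numbers. Compound 1 stands at 31.7 uM, higher than compound 2 and beyond the usual scatter. The two compounds differ in more than one place, so this gap cannot be tied to any single structural change.

The next compound is compound 3 `CCCCCCCCCCc1c(C)cc2[n+](c1C)CCC2`, still unmeasured. Its change from compound 2 is hydrogen in place of decyl on an aromatic carbon. For the measured compounds named here, the series offers no measured one-place step to calibrate this change, so the expectation remains loose. A moderate move toward a higher number is expected, probably beyond the scatter, but with no-change within the scatter not excluded. The expected step is a 3.2-fold higher number from compound 2 to compound 3 (0.50 log units; beyond the scatter) in this assay for now. The estimated value for compound 3 is 6 uM (expected range 2 uM to 20 uM) pending measurement.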

Compound 3, concentration for half-maximal effect: 1.7 uM
The estimate for compound 3 lay 3.5-fold (0.55 log units) above the measured number; the measured number lies below the stated range.
By their numbers in this assay, from the lowest: compounds 3 and 2 (each within the scatter of the next); then compound 1.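

For the compounds shown here, the first one-place step concerns the aromatic carbon ortho to a fused ring and ortho to a methyl group. In this assay, replacing decyl with hydrogen at this carbon gives a 1.1-fold lower number from compound 2 to compound 3 (0.05 log units; within the scatter). A group of 10 heavy atoms can therefore leave this position without a readable change in the number, so a decyl group here is not required for the low value seen with compound 2, at least while the decyl group meta to this position stays in place. The compounds offer no measured basis for explaining why the number holds when the chain leaves.

Going by these compounds, the step covers only the two extremes at this position, decyl and hydrogen, so it remains open whether a shorter chain such as butyl, or an amine or a carboxylic acid, would also leave the number in place. Going by these compounds alone, also open is whether the remaining decyl group can be shortened or replaced in the same way, since compound 2 and compound 3 both carry it and no step here tests that position.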